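This account rests on a few compounds, and the source may have more. Where it says the series, first, only, none or still open, it means among the compounds named here.

Measured compounds and their values:
compound 1 `COc1ccc(NC(=O)c2ccc3cccc(O)c3n2)cc1`: 2.5
compound 2 `Cc1cccc(NC(=O)c2ccc3cccc(O)c3n2)c1`: 2.5

In a physicochemical assay for lipophilicity, read by HPLC (on this read-out higher numbers stand for higher lipophilicity and lower numbers for lower lipophilicity), compound 1 gives 2.5. Compound 2 gives 2.5 in this assay, level with compound 1 at the digits shown; the two values lie within the scatter of repeated measurements, so no difference between them can be read from the numbers.

Compound 3 `Cc1ccc(NC(=O)c2ccc3cccc(O)c3n2)cc1` has not yet been measured. It differs from compound 2 in one place: 4-methylphenyl in place of 3-methylphenyl on an amide-type nitrogen. The two have the same atoms, joined differently, so nothing is added to or removed from the molecule. Among the compounds with values here, no step between measured compounds covers a rearrangement of this kind, so the measured pair gives no direct guide to it. Within the data shown here, since the same atoms remain and the single methyl group simply sits elsewhere on the phenyl ring, the expectation is that the value stays where compound 2 stands, with no step beyond the scatter in either direction. Compound 3 is therefore expected to give 2.5, likely between 2.2 and 2.8. The expected step of no change at the digits printed from compound 2 to compound 3 (within the scatter) is none beyond the scatter.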

Compound 3, partition coefficient: 2.5
Beside the measured number, compound 3's estimate shows no gap at the digits printed, and the stated range covers the measured number.
By their numbers in this assay, from the lowest: compounds 1, 2 and 3 (each within the scatter of the next).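

Within the data shown here, compound 3 gives the first direct comparison of where the methyl group sits on the ring attached to the amide-type nitrogen: in this assay, 4-methylphenyl in place of 3-methylphenyl gives no change at the digits printed from compound 2 to compound 3 (within the scatter), so this rearrangement of the same atoms leaves no readable mark on this read-out. It also supplies a single-place comparison for the group on the aromatic carbon, since methyl in place of methoxy gives no change at the digits printed from compound 1 to compound 3 (within the scatter), and this swap likewise stays within the scatter in this assay. No supporting measurement accounts for these level values, so the numbers record the outcome without explaining it.

On these data alone, these three compounds cover only methyl and methoxy groups on this phenyl ring, so it remains open whether an amine, a carboxylic acid or a longer alkyl chain there would move the value beyond the scatter. As far as these compounds go, it is also open whether the level readings seen for these changes would carry over to a different core or to any other kind of measurement.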